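Replacing a pentyl chain with a methoxyphenyl ring

This account rests on a few compounds, and the source may have more. Where it says the series, first, only, none or still open, it means among the compounds named here.

Compound 1 `CCCCCNc1nc(NCc2ccco2)c2cc(F)ccc2n1` is the reference point of this set. In a functional assay on HCT-116 cells (Homo sapiens) for cytotoxicity, read by MTT assay, with a stated time of 2 days (on this read-out lower numbers stand for stronger inhibition and higher numbers for weaker inhibition), compound 1 gives 4100 nM, the lowest of the two numbers reported. Its nearest neighbour, compound 2 `c1coc(CNc2nc(NCCCN3CCCC3)nc3ccccc23)c1`, gives 16100 nM in this assay, a gap that lies beyond the usual scatter. In this assay compound 3 `CCCCCNc1nc(NCc2ccco2)c2ccccc2n1` is recorded as "not determined" (no result reported), so no number is available for it. Compound 4 `COc1ccc(Nc2nc(NCc3ccco3)c3cc(F)ccc3n2)cc1` differs from compound 1 in one place: 4-methoxyphenyl in place of pentyl on a nitrogen on an aromatic ring. Among the measured compounds shown here, no measured pair in the set shows this kind of change, so the size of the step is uncertain. He expects a modest move toward stronger inhibition, a 2.1-fold lower number from compound 1 to compound 4 (0.31 log units; beyond the scatter), though a result within the scatter would not surprise. Compound 4 is therefore estimated at 2000 nM, within a range from 400 nM to 10000 nM.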

Compound 4, half-maximal inhibitory concentration: 6150 nM
Compound 4: middle estimate off by 3.1-fold (0.49 log units), on the low side; measured number inside the range.
By their numbers in this assay, from the lowest: compounds 1 and 4 (each within the scatter of the next); then compound 2.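

In this assay the exchange of pentyl for 4-methoxyphenyl gives a 1.5-fold higher number from compound 1 to compound 4 (0.18 log units; within the scatter) on a nitrogen on an aromatic ring, so at this place an open chain and a six-membered aromatic ring cannot be told apart. Nothing in the data bears on the reason for this result. The compounds shown leave open whether an unsubstituted phenyl ring, a longer chain or a carboxylic acid at this place would read the same. Going by these compounds, the part played by the fluorine of compound 1 also stays open, as compound 3 carries no number.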